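Trading a phenyl for hydrogen in compound 2

This account rests on a few compounds, and the source may have more. Where it says the series, first, only, none or still open, it means among the compounds named here.

In a functional assay on MM1.S cells (Homo sapiens) for cytotoxicity, read by MTT assay, with a stated time of 48 h (a lower number here means a stronger inhibitor, a higher number a weaker inhibitor), compound 2 `ClC1=C(Cl)C(Cl)=C(Cl)C1=NN(c1ccccc1)c1ccccc1` gives no number, only the limit > 3000 nM. The other two measured compounds do give numbers: compound 1 `O=C(c1ccc(F)cc1)N(N=C1C(Cl)=C(Cl)C(Cl)=C1Cl)C(=O)c1ccc(F)cc1` stands at 300 nM and compound 3 `O=C(NN=C1C(Cl)=C(Cl)C(Cl)=C1Cl)c1ccccc1` at 800 nM. Compound 4 `ClC1=C(Cl)C(Cl)=C(Cl)C1=NNc1ccccc1` differs from compound 2 by a single change, hydrogen in place of phenyl on a nitrogen (hydrogen in place of phenyl on a nitrogen on an aromatic ring). Among the compounds with values here, no measured pair isolates this change. The nearest guide is compound 3, which also carries a hydrogen on that nitrogen and gives 800 nM. In this assay, the step of an at least 2.5-fold lower number from compound 2 to compound 4 (0.39 log units; beyond the scatter) is therefore expected to be a moderate gain in strength, although the limit leaves its true size open. Compound 4 is estimated at 1200 nM, with an expected range of 400 nM to 3000 nM.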

Compound 4, half-maximal inhibitory concentration: 2000 nM
For compound 4 the middle estimate is 1.7-fold (0.22 log units) below the measured one; the measured number falls inside the stated range.
By their numbers in this assay, from the lowest: compound 1; then compound 3; then compound 4. At a limit, above all of these: compound 2.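

In this assay, compound 2 remains a limit, > 3000 nM. With hydrogen in place of phenyl on this nitrogen, compound 4 brings the position onto a measurable scale, with an at least 1.5-fold lower number from compound 2 to compound 4 (0.17 log units; that floor lies within the scatter). Only a floor is known for this step, so a real gain from the change is not established, and its true size stays open: the limit of > 3000 nM in this assay, at which 1 of the 4 values shown sits.

On these data alone, it remains open whether a methyl group or a longer alkyl chain on this nitrogen would behave like hydrogen or like phenyl. A carboxylic acid on the phenyl of compound 4 is equally unaddressed.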